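The compounds below may be only part of what the source reports. "The series", "measured", "known", "first", "only" and "open" are said of these compounds alone.

In a functional assay on CCRF-CEM cells (Homo sapiens) for cytotoxicity, read by sulforhodamine B assay, with a stated time of 48 h (a lower number here means a stronger inhibitor of growth, a higher number a weaker inhibitor of growth), compound 1 `ClCc1ccccc1Cn1cnc2c(Cl)ncnc21` gives 1280 nM, compound 2 `ClCc1cccc(Cn2cnc3ncnc(Cl)c32)c1` gives 6910 nM, and compound 3 `ClCc1ccc(Cn2cnc3nc(Cl)nc(Cl)c32)cc1` gives 14800 nM. Among these three numbers compound 2 stands second highest, lying beyond the scatter from both of the others. Compound 4 `ClCc1cccc(Cn2cnc3nc(Cl)nc(Cl)c32)c1` has not yet been measured. It differs from compound 2 by a single change: chloro in place of hydrogen on an aromatic carbon. Going by the values given here, no pair of measured compounds differs by this change alone, so its effect is not known directly. Compound 3 carries the same second chloro and gives the highest number of the three, but it also differs from compound 2 elsewhere, so it offers only a loose hint. For compound 4 a modest rise in this assay is expected, a 1.4-fold higher number from compound 2 to compound 4 (0.16 log units; within the scatter), giving an estimate of 10000 nM with a range from 3500 nM to 30000 nM.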

Compound 4, concentration for 50% growth inhibition: 1380 nM
Compound 4: middle estimate off by 7.2-fold (0.86 log units), on the high side; measured number below the stated range.
By their numbers in this assay, from the lowest: compounds 1 and 4 (each within the scatter of the next); then compound 2; then compound 3.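

In this assay chloro in place of hydrogen on this aromatic carbon, between two ring nitrogen atoms, gives a 5.0-fold lower number from compound 2 to compound 4 (0.70 log units; beyond the scatter) and so yields a stronger growth inhibitor. The earlier compounds shown here could not isolate this change, and this single pair now shows that the position affects the read-out. Nothing available here accounts for the drop.

Going by these compounds, whether an amine or a methoxy group at this position would act like chloro remains open. So does whether chloro would have the same effect with the chloromethyl group placed elsewhere.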